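A few compounds are considered here, and "the series" means these few. Any claim that something is new, unique, unknown or untested is made for them only; others in the source may bear on it.

Compound 1, with structure `Cn1cc(/C=C2\C(=O)Nc3ccc(S(N)(=O)=O)cc32)c2ccccc21`, gives 90% in an assay on isolated protein for inhibition of Ephrin type-A receptor 2 (Homo sapiens), tested at 1 uM; a higher number here means a weaker effect of the compound at the concentration tested, a lower number a stronger effect.
Compound 2, with structure `CN(C)S(=O)(=O)c1ccc2c(c1)/C(=C/c1cn(C)c3ccc(O)cc13)C(=O)N2`, gives 98% in this assay.
Compound 3, with structure `COc1ccc2c(c1)c(/C=C1\C(=O)Nc3ccc(S(=O)(=O)N(C)C)cc31)cn2C`, gives 89% in this assay.

All three numbers lie close together. Compound 3 has the smallest value of the three, yet its distance to compound 1 and to compound 2 is in each case within the usual scatter, so no real ordering among them can be claimed. Among the measured compounds shown here, the one single-point step among the measured compounds, a number 9 percentage points lower from compound 2 to compound 3 (within the scatter), concerns an oxygen on an aromatic ring and therefore says nothing about the change at hand.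

Compound 4, with structure `COc1ccc2c(c1)c(/C=C1\C(=O)Nc3ccc(S(N)(=O)=O)cc31)cn2C`, differs from compound 3 in one place: amino in place of dimethylamino on a sulfonyl sulfur. For the measured compounds named here, no measured step covers this exact change. Compound 1 carries the sulfamoyl group and compound 3 the dimethylsulfamoyl group, but they differ in a second place too, so only their two values, which are within the scatter of each other, can be compared. On that basis no step beyond the scatter is expected. Compound 4 is expected to give about 90% in this assay, with a likely range from 76% to 100%. This estimate means an expected step of a number 1 percentage points higher from compound 3 to compound 4 (within the scatter).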

Compound 4, a percentage reported as activity, at one concentration (the size of the read-out at that concentration, not a potency): 89%
Beside the measured number, compound 4's estimate is 1 percentage points above it; the measured number falls inside the stated range.
By their numbers in this assay, from the lowest: compounds 3, 4, 1 and 2 (each within the scatter of the next).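

Exchanging dimethylamino for amino on a sulfonyl sulfur can now be read directly, and it gives no change at the digits printed from compound 3 to compound 4 (within the scatter) in this assay, so with the methoxy group present the two groups cannot be told apart at this place. The second single-place comparison, methoxy in place of hydrogen on an aromatic carbon, gives a number 1 percentage points lower from compound 1 to compound 4 (within the scatter), so with the sulfamoyl group present that exchange cannot be told apart from the scatter either. No available evidence bears on these results.

The compounds shown therefore leave open whether any group on the sulfonyl sulfur can shift the read-out beyond the scatter. Whether a cyclic amine such as morpholine or a longer chain such as diethylamino at that place would do so remains unanswered.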